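Removing one trifluoromethyl from a diaryl urea growth inhibitor

The source may report more compounds than this note shows. Statements on the series, on what has been measured and on what is new or still open speak of the compounds shown alone.

Measured compounds:
compound 1, `O=C(Nc1cccc(-n2cc(-c3ccncc3)c(-c3ccc(Cl)c(O)c3)n2)c1)Nc1cc(C(F)(F)F)cc(C(F)(F)F)c1`: 1490 nM
compound 2, `COc1cc(-c2nn(-c3cccc(NC(=O)c4ccccc4)c3)cc2-c2ccncc2)ccc1Cl`: 2880 nM

Of the compounds shown here, two have been measured in a functional assay on SF-539 cells (Homo sapiens) for inhibition, read by sulforhodamine B assay, with a stated time of 48 h; a higher number here means a weaker inhibitor of growth, a lower number a stronger inhibitor of growth. Compound 1 gives 1490 nM in this assay, and compound 2 gives 2880 nM. The gap between them lies within the usual scatter, so the two numbers do not separate compound 1 from compound 2.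

Compound 3, `O=C(Nc1cccc(-n2cc(-c3ccncc3)c(-c3ccc(Cl)c(O)c3)n2)c1)Nc1cccc(C(F)(F)F)c1`, is not yet measured. It keeps the core of compound 1 and differs in one place: hydrogen in place of trifluoromethyl on an aromatic carbon. Within the data shown here, no measured pair shows what this change does in this assay, so the step from compound 1 to compound 3 can only be guessed. Because compound 1 sits at 1490 nM with a substantial aromatic group on each side of the urea, a modest weakening is expected when one trifluoromethyl is replaced by hydrogen, with the step of a 1.5-fold higher number from compound 1 to compound 3 (0.17 log units; within the scatter) likely close to the scatter. For compound 3 the expected value in this assay is 2200 nM, within a range of 900 nM to 6000 nM.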

Compound 3, concentration for total growth inhibition: 11600 nM
Estimate against measurement, compound 3: 5.3-fold (0.72 log units) below, outside the stated range (above it).
By their numbers in this assay, from the lowest: compounds 1 and 2 (each within the scatter of the next); then compound 3.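

Among these compounds, the only one-place step in this assay shows that this aromatic carbon matters for growth inhibition: hydrogen in place of trifluoromethyl brings a 7.8-fold higher number from compound 1 to compound 3 (0.89 log units; beyond the scatter). The second trifluoromethyl is therefore not interchangeable with hydrogen at this position, even with the other trifluoromethyl and the rest of the core of compound 1 left unchanged. Nothing at hand accounts for the size of this step.

On these data alone, it remains open whether the lower number of compound 1 depends on trifluoromethyl itself or whether another substituent on this carbon would serve as well; chlorine, methyl or a nitrile there would begin to separate these readings. A single pair also leaves open whether the same change would have a similar effect on a different core.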